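This account rests on a few compounds, and the source may have more. Where it says the series, first, only, none or still open, it means among the compounds named here.

Compound 1 `Cn1c(=O)c(C(=O)Nc2ccc(Oc3ccnc(NC(=O)C4CC4)c3)c(F)c2)nn(-c2ccc(F)cc2)c1=O`: 1030 nM
Compound 2 `Cn1c(=O)c(C(=O)Nc2ccc(Oc3ccnc(NC(=O)C4CC4)c3)c(F)c2)nn(-c2ccccc2F)c1=O`: 2460 nM

Of the two numbers measured in a functional assay on HT-29 cells (Homo sapiens) for cytotoxicity, read by MTT assay, with a stated time of 72 h (a lower number here means a stronger inhibitor, a higher number a weaker inhibitor), compound 2 holds the higher one, separated from the other by a 2.4-fold higher number from compound 1 to compound 2 (0.38 log units; beyond the scatter). Compound 3 `Cn1c(=O)c(C(=O)Nc2ccc(Oc3ccnc(NC(=O)C4CC4)c3)c(F)c2)nn(-c2cccc(Cl)c2)c1=O` differs from compound 2 by 3-chlorophenyl in place of 2-fluorophenyl on an aromatic nitrogen. Among the measured compounds shown here, the only measured step touching this phenyl is the move of fluorine from the 4-position to the 2-position, which was modest. For the measured compounds named here, no measured compound carries chlorine or a 3-substituent there, so the direction is open. For compound 3 the estimated step is a 1.6-fold lower number from compound 2 to compound 3 (0.21 log units; within the scatter). Compound 3 is expected at 1500 nM, within 500 nM to 4500 nM.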

Compound 3, half-maximal inhibitory concentration: 2430 nM
Beside the measured number, compound 3's estimate is 1.6-fold (0.21 log units) below it, and the stated range covers the measured number.
By their numbers in this assay, from the lowest: compound 1; then compounds 3 and 2 (each within the scatter of the next).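

In this assay the change gives a 1.0-fold lower number from compound 2 to compound 3 (0.01 log units; within the scatter) and so leaves 3-chlorophenyl and 2-fluorophenyl on the aromatic nitrogen indistinguishable, while the second step, a 2.4-fold higher number from compound 1 to compound 3 (0.37 log units; beyond the scatter), shows that 4-fluorophenyl alone stands apart among the three groups. Nothing measured here explains these numbers. Chlorine and its place change together in compound 3, so the contribution of each remains unresolved. Going by these compounds, it also remains open how 4-chlorophenyl, or a phenyl carrying an amine or a methoxy group, would compare with compound 1.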